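Nitro to Chloro Swap Tested on Two Related Cores

The source may hold more compounds than are shown below. What is called first, only, known or untested is meant among the compounds shown, and "the series" means these compounds.

Compound 1 `COc1cc(-c2ncnn2-c2ccc([N+](=O)[O-])cc2)cc(OC)c1OC` and compound 2 `COc1cc(-c2ncnn2-c2ccc(Cl)cc2)cc(OC)c1OC` share one core and differ by chloro in place of nitro on an aromatic carbon. In a functional assay on K562 cells (Homo sapiens) for antiproliferative activity, read by MTT assay, with a stated time of 72 h (on this read-out lower numbers stand for stronger inhibition and higher numbers for weaker inhibition), compound 1 gives only a limit of the assay, > 10000 nM. In this assay compound 2 likewise gives only a limit, > 10000 nM. The step that the two limits leave unreadable from compound 1 to compound 2 therefore cannot be sized. Compound 3 `COc1cc(-n2ncnc2-c2cccc([N+](=O)[O-])c2)cc(OC)c1OC` has the same atoms as compound 1 joined differently; the difference between the two cores is not broken down here. In this assay compound 3 again gives only a limit, > 10000 nM. Compound 4 `COc1cc(-n2ncnc2-c2cccc(Cl)c2)cc(OC)c1OC` is not yet measured and differs from compound 3 by chloro in place of nitro on an aromatic carbon. In compound 1 the changed carbon is para to a large group, in compound 3 meta to a large group, so this is the same kind of change rather than the same one. Because every measured value sits at the limit of > 10000 nM in this assay, at which 3 of the 3 values shown sit, the expected step is a step that the limit leaves unreadable from compound 3 to compound 4. Compound 4 is expected to give 20000 nM, between 7000 nM and 60000 nM.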

Compound 4, half-maximal inhibitory concentration: > 10000 nM
Compound 4 was reported as a limit; the forecaster's own chance of this, stated with the estimate: 85%; the middle value lies beyond the limit too.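

Within the data shown here, no step from nitro to chloro can be read between compound 3 and compound 4, since both are reported only as limits: the limit of > 10000 nM in this assay, at which 4 of the 4 values shown sit. The compounds shown leave open whether swapping nitro for chloro changes activity at all, on either core.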